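The compounds below may be only part of what the source reports. "The series", "measured", "known", "first", "only" and "open" are said of these compounds alone.

Measured so far:
compound 1 `CCOc1ccc(C2C(C3CC3)C(=O)N2c2cc(OC)c(OC)c(OC)c2)cc1` — 131 nM
compound 2 `COc1cc(N2C(=O)C(C3CC3)C2c2ccc(SC)cc2)cc(OC)c1OC` — 131 nM
compound 3 `CCOc1ccc(C2C(O)C(=O)N2c2cc(OC)c(OC)c(OC)c2)cc1` — 7 nM

In a functional assay on MCF7 cells (Homo sapiens) for inhibition, read by resazurin assay, with a stated time of 72 h (a lower number here means a stronger inhibitor, a higher number a weaker inhibitor), compound 1 gives 131 nM and compound 2 gives 131 nM; the change methylsulfanyl in place of ethoxy on an aromatic carbon produced no change at the digits printed from compound 1 to compound 2 (within the scatter). The cores of compound 1 and compound 3 differ by hydroxy in place of cyclopropyl on a saturated ring carbon, and this gave a 19-fold lower number from compound 1 to compound 3 (1.27 log units; beyond the scatter), so compound 3 holds the lowest of the three numbers in this assay.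

Compound 4 `COc1cc(N2C(=O)C(O)C2c2ccc(SC)cc2)cc(OC)c1OC` is not yet measured. It differs from compound 3 by methylsulfanyl in place of ethoxy on an aromatic carbon, at a place described in the same words as for the change from compound 1 to compound 2, so it is the same change on the other core. Because no change at the digits printed from compound 1 to compound 2 (within the scatter) lay within the scatter, the step of no change at the digits printed from compound 3 to compound 4 (within the scatter) is expected to be small as well. Compound 4 is therefore estimated at 7 nM in this assay, expected to fall between 3 nM and 18 nM.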

Compound 4, half-maximal inhibitory concentration: 5 nM
Estimate against measurement, compound 4: 1.4-fold (0.15 log units) above, within the range that was stated.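

In this assay the change from 4-ethoxyphenyl to 4-(methylsulfanyl)phenyl on the hydroxy-bearing core gives a 1.4-fold lower number from compound 3 to compound 4 (0.15 log units; within the scatter) and so carries over from the cyclopropyl-bearing core: the same change on two cores in this assay, no change at the digits printed (within the scatter) from compound 1 to compound 2 and a 1.4-fold lower number (0.15 log units; within the scatter) from compound 3 to compound 4, 1.4-fold (0.15 log units) apart, within the scatter of two such steps

Hydroxy in place of cyclopropyl gives a 26-fold lower number from compound 2 to compound 4 (1.42 log units; beyond the scatter) with methylsulfanyl on the aromatic ring, so this large step holds with either group there: the same change on two cores in this assay, a 19-fold lower number (1.27 log units; beyond the scatter) from compound 1 to compound 3 and a 26-fold lower number (1.42 log units; beyond the scatter) from compound 2 to compound 4, 1.4-fold (0.15 log units) apart, within the scatter of two such steps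

The two changes therefore combine without visible interaction across these four compounds, but this rests on a single set of pairs in one assay and shows neither a cause nor any transfer to other cores.

Still open, as far as these compounds go, is how an amine or a fluorine in place of the hydroxy would read in this assay. Also open, from the compounds shown here alone, is whether a longer chain in place of ethoxy or methylsulfanyl would keep the step as small.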